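Extending the chain before the methylsulfonylpiperazine

This account rests on a few compounds, and the source may have more. Where it says the series, first, only, none or still open, it means among the compounds named here.

In an assay on HEK293 cells for displacement of a labelled ligand from 5-hydroxytryptamine receptor 4 (Homo sapiens), read by scintillation counting (on this read-out higher numbers stand for weaker inhibition and lower numbers for stronger inhibition), compound 1 `COc1cc(N)c(Cl)cc1C(=O)NC1CCN(CCCCCO)CC1` gives 63.1 nM, the lowest of the three numbers recorded so far. Compound 2 `COc1cc(N)c(Cl)cc1C(=O)NC1CCN(CCN2CCCCC2)CC1` gives 251 nM in this assay, and compound 3 `COc1cc(N)c(Cl)cc1C(=O)NC1CCN(CCN2CCN(S(C)(=O)=O)CC2)CC1` gives 126 nM. Between them, a 4.0-fold higher number from compound 1 to compound 2 (0.60 log units; beyond the scatter) and a 2.0-fold higher number from compound 1 to compound 3 (0.30 log units; within the scatter) describe the two changes made at the end of the short chain on the ring nitrogen, and a 2.0-fold lower number from compound 2 to compound 3 (0.30 log units; within the scatter) compares the two ring-capped chains with each other. Within the data shown here, only the step to compound 2 lies beyond the scatter; the other two do not.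

Compound 4 `COc1cc(N)c(Cl)cc1C(=O)NC1CCN(CCCCCN2CCN(S(C)(=O)=O)CC2)CC1` keeps the shared core of compound 1 and its five-carbon chain, with the change (4-(methylsulfonyl)piperazin-1-yl in place of hydroxy on a saturated chain carbon, five bonds along the chain from an amine nitrogen in a ring). Among the measured compounds shown here, the step that bears on it most is the one from compound 1 to compound 3, where the same group replaced a shorter chain end and the number moved only within the scatter. Nothing measured speaks to the longer chain in the same setting. In this assay compound 4 is therefore expected to land close to compound 1, with a 1.6-fold higher number from compound 1 to compound 4 (0.20 log units; within the scatter) as the likely step. The estimate for compound 4 is 100 nM, within a range from 40 nM to 250 nM.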

Compound 4, inhibition constant: 39.8 nM
The estimate for compound 4 lay 2.5-fold (0.40 log units) above the measured number, outside the stated range (below it).
By their numbers in this assay, from the lowest: compounds 4, 1, 3 and 2 (each within the scatter of the next, the first and the last beyond it).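

In this assay, a single hydroxy on a saturated chain carbon, five bonds along the chain from an amine nitrogen in a ring, gives way to 4-(methylsulfonyl)piperazin-1-yl, which brings 10 heavy atoms and a six-membered ring in place of 1 heavy atom, and the result is a 1.6-fold lower number from compound 1 to compound 4 (0.20 log units; within the scatter). Among these compounds, this position therefore accepts a much larger end group carrying no hydrogen-bond donor, with no loss beyond the scatter, something the earlier compounds could show only on a shorter chain. With the same end group on both, compound 3 gives 126 nM on the shorter chain and compound 4 gives 39.8 nM on the longer one; no measurement shown here accounts for this result.

The compounds shown leave open whether piperidin-1-yl on the longer chain would match compound 4, which would indicate how much the methylsulfonyl group matters at this distance. They also leave open how a still longer chain, or a chain of intermediate length ending in the same 4-(methylsulfonyl)piperazin-1-yl, would read in this assay.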